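This account rests on a few compounds, and the source may have more. Where it says the series, first, only, none or still open, it means among the compounds named here.

Of the compounds shown here, three built on a shared core have been tested in a functional assay on MCF7 cells (Homo sapiens) for inhibition, read by MTT assay, with a stated time of 48 h; a lower number here means a stronger inhibitor, a higher number a weaker inhibitor. Compound 1 `Fc1ccc(CSc2nnc(-c3ccncc3)n2-c2ccccc2)c(F)c1` gives 14100 nM. Going by the values given here, compound 2 `O=[N+]([O-])c1ccc(CSc2nnc(-c3ccncc3)n2-c2ccccc2)cc1` gives 22800 nM in this assay, and the step of a 1.6-fold higher number from compound 1 to compound 2 (0.21 log units; within the scatter) is the only single-point change measured so far. Compound 3 `O=C(CSc1nnc(-c2ccncc2)n1-c1ccccc1)N/N=C/c1ccc(Br)cc1` gives 7040 nM in this assay, the lowest of the three numbers; it lies within the scatter of compound 1 but beyond the scatter of compound 2, so it cannot be called the strongest outright.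

Compound 4 `O=C(CSc1nnc(-c2ccncc2)n1-c1ccccc1)N/N=C/c1ccc(O)c(O)c1` has not yet been measured. It differs from compound 3 in one place: 3,4-dihydroxyphenyl in place of 4-bromophenyl on a carbon with a double bond to nitrogen. Among the compounds with values here, the only measured step, a 1.6-fold higher number from compound 1 to compound 2 (0.21 log units; within the scatter), swaps one aromatic group for another at a different place in the molecule and stayed within the scatter, so it bears on the present change only loosely. Within the data shown here, no step at the carbon with a double bond to nitrogen has been measured, so no step beyond the scatter is expected. For compound 4 the expected value in this assay is 6500 nM, with a range from 2500 nM to 17000 nM. The expected step is therefore a 1.1-fold lower number from compound 3 to compound 4 (0.03 log units; within the scatter).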

Compound 4, half-maximal inhibitory concentration: 19700 nM
For compound 4 the middle estimate is 3.0-fold (0.48 log units) below the measured one; the measured number lies above the stated range.
By their numbers in this assay, from the lowest: compounds 3, 1, 4 and 2 (each within the scatter of the next, the first and the last beyond it).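

In this assay, going by these compounds alone, the carbon with a double bond to nitrogen proves sensitive to the group it carries: 3,4-dihydroxyphenyl in place of 4-bromophenyl gives a 2.8-fold higher number from compound 3 to compound 4 (0.45 log units; beyond the scatter), whereas the one earlier step, made elsewhere in the molecule, stayed within the scatter. This single swap changes several things at once, since bromine leaves and hydroxyl groups enter, bringing hydrogen-bond donors and acceptors that the 4-bromophenyl group lacks, so the compounds shown cannot say which part of the swap matters. No measurement is available that explains the direction or size of this step.

Still open, as far as these compounds go, is whether 4-hydroxyphenyl, with a single hydroxyl group, or 3,4-dimethoxyphenyl, with methoxy groups instead, would read closer to compound 3 or to compound 4. It is also unknown whether 4-chlorophenyl or unsubstituted phenyl would behave like the 4-bromophenyl group here.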